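Methyl for fluoro on the aryl-piperazine of compound 2

The compounds below may be only part of what the source reports. "The series", "measured", "known", "first", "only" and "open" are said of these compounds alone.

Of the compounds shown here, two of one family have been measured so far. Compound 1 `COc1ccc(N2CCN(C(=S)SCc3ccc(C(=O)Nc4ccccc4N)cc3)CC2)cc1` gives 39.4% in a functional assay on HeLa cells (Homo sapiens) for antiproliferative activity, read by CCK-8 assay, with a stated time of 72 h, tested at 2 uM; on this read-out lower numbers stand for a weaker effect and higher numbers for a stronger effect at the one concentration tested. For the measured compounds named here, compound 2 `Nc1ccccc1NC(=O)c1ccc(CSC(=S)N2CCN(c3ccc(F)cc3)CC2)cc1` gives 60.8% in this assay, the higher of the two numbers, the only neighbour being compound 1, which stands lower. Going by the values given here, the single step between them is a number 21.4 percentage points higher from compound 1 to compound 2 (beyond the scatter).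

Compound 3 `Cc1ccc(N2CCN(C(=S)SCc3ccc(C(=O)Nc4ccccc4N)cc3)CC2)cc1` is the next member to be tested. Its difference from compound 2 is methyl in place of fluoro on an aromatic carbon. Among the compounds with values here, the only measured step, a number 21.4 percentage points higher from compound 1 to compound 2 (beyond the scatter), concerns methoxy and fluoro at this same position, and it shows that a change there can move the read-out beyond the scatter; no measured step involves methyl, so the direction for compound 3 is not fixed by the numbers at hand. The two values bracket a moderate range, and compound 3 is expected to fall inside it. For compound 3 the estimate is 50%, with a range from 30% to 70%. This estimate means an expected step of a number 10.8 percentage points lower from compound 2 to compound 3 (beyond the scatter).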

Compound 3, a percentage reported as inhibition, at one concentration (the size of the read-out at that concentration, not a potency): 25.3%
The estimate for compound 3 lay 24.7 percentage points above the measured number; the measured number lies below the stated range.
By their numbers in this assay, from the lowest: compound 3; then compound 1; then compound 2.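

In this assay, methyl does not fall inside the span set by methoxy and fluoro at this position: the change from 4-fluorophenyl to 4-methylphenyl gives a number 35.5 percentage points lower from compound 2 to compound 3 (beyond the scatter), and replacing methoxy with methyl gives a number 14.1 percentage points lower from compound 1 to compound 3 (beyond the scatter). The earlier compounds shown here showed only that this position could respond to a change, whereas the new result shows that exchanging one heavy atom for one heavy atom, with no ring, hydrogen-bond donor or acceptor on either side, can produce a large step. All three substituents now stand apart beyond the scatter, with compound 3 lowest, compound 1 in the middle and compound 2 highest, so at this one concentration the position separates fluoro, methoxy and methyl clearly.

Nothing available explains why the three groups fall in this order. Going by these compounds, it also remains open where a chloro group, an amine or a hydroxyl group on the same aromatic carbon would stand, and whether the order of compound 1, compound 2 and compound 3 would hold at other concentrations.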